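This account rests on a few compounds, and the source may have more. Where it says the series, first, only, none or still open, it means among the compounds named here.

In a functional assay on MCF7 cells (Homo sapiens) for antiproliferative activity, read by MTT assay, with a stated time of 48 h (on this read-out lower numbers stand for stronger inhibition and higher numbers for weaker inhibition), compound 3 `Cc1ccc(NCc2cn(-c3ccccc3)nc2-c2ccc(Br)cc2)cc1` gives 5380 nM, within the scatter of compound 2 `COc1ccc(-c2nn(-c3ccccc3)cc2CNc2ccc(F)cc2)cc1` at 5980 nM, while compound 1 `Fc1ccc(NCc2cn(-c3ccccc3)nc2-c2ccc(Cl)cc2)cc1` reads lower at 1880 nM. Compound 4 `Fc1ccc(NCc2cn(-c3ccccc3)nc2-c2ccc(Br)cc2)cc1` has fluoro in place of methyl on an aromatic carbon, para to a large group (fluoro in place of methyl on an aromatic carbon). Going by the values given here, no measured step makes this change. Among the compounds with values here, the only measured step, a 3.2-fold higher number from compound 1 to compound 2 (0.50 log units; beyond the scatter), is modest and swaps chloro for methoxy elsewhere, while both compounds already carry the fluoro of compound 4. Of those two, only compound 1 at 1880 nM reads lower than compound 3, and compound 2 goes against any gain from fluoro. A small move to a lower number is expected, a 2.1-fold lower number from compound 3 to compound 4 (0.32 log units; beyond the scatter). Compound 4 is estimated at 2600 nM, within an expected range of 1000 nM to 6500 nM.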

Compound 4, half-maximal inhibitory concentration: 3960 nM
Estimate against measurement, compound 4: 1.5-fold (0.18 log units) below; measured number inside the range.
By their numbers in this assay, from the lowest: compound 1; then compounds 4, 3 and 2 (each within the scatter of the next).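

Changing (4-methylphenyl)amino to (4-fluorophenyl)amino, with bromo held in place, gives a 1.4-fold lower number from compound 3 to compound 4 (0.13 log units; within the scatter), so this position shows no clear response to the swap. Going by these compounds alone, with fluoro held in place, bromo in place of methoxy gives a 1.5-fold lower number from compound 2 to compound 4 (0.18 log units; within the scatter), whereas bromo in place of chloro gives a 2.1-fold higher number from compound 1 to compound 4 (0.32 log units; beyond the scatter), leaving chloro as the one group of these three that stands apart. Nothing measured here explains these numbers.

The compounds shown leave open how a hydroxyl or a nitrile would read at this position, and whether the swap from methyl to fluoro would behave the same with chloro in place of bromo.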